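The source may hold more compounds than are shown below. What is called first, only, known or untested is meant among the compounds shown, and "the series" means these compounds.

Working notes on the series. In a functional assay on MIA PaCa-2 cells (Homo sapiens) for inhibition, read by MTT assay, with a stated time of 72 h (on this read-out higher numbers stand for weaker inhibition and lower numbers for stronger inhibition), compound 1 (`COc1cc(NC(C)CCCNC(=O)Nc2cccc(Cl)c2)c2ncccc2c1`) gives 21000 nM. Compound 2 (`COc1cc(NC(C)CCCNC(=O)Nc2cccc(O)c2)c2ncccc2c1`) gives 46000 nM, the higher of the two numbers and therefore the weaker inhibition. For the measured compounds named here, the only measured step is a 2.2-fold higher number from compound 1 to compound 2 (0.34 log units; beyond the scatter), with hydroxy in place of chloro on an aromatic carbon, and it is modest.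

Compound 3 (`COc1cc(NC(C)CCCNC(=O)NNC(=O)Nc2cccc(F)c2)c2ncccc2c1`) has not yet been measured. The change leading to it is ((3-fluorophenyl)carbamoyl)amino in place of 3-hydroxyphenyl on an amide-type nitrogen. Going by the values given here, this is a larger change than the measured step, and no measured compound carries the entering group, so that step bears on it only in part. The entering group carries fluoro rather than hydroxy, and the chloro-bearing compound 1 has the lower number at 21000 nM. On that basis, a small move towards a lower number is expected in this assay, no larger than the measured step and possibly within the scatter. The expected change is a 1.8-fold lower number from compound 2 to compound 3 (0.26 log units; within the scatter). Compound 3 is estimated at 25000 nM, with an expected range of 8000 nM to 80000 nM.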

Compound 3, half-maximal inhibitory concentration: 69000 nM
Beside the measured number, compound 3's estimate is 2.8-fold (0.44 log units) below it; measured number inside the range.
By their numbers in this assay, from the lowest: compound 1; then compounds 2 and 3 (each within the scatter of the next).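

Working from this assay, the larger ((3-fluorophenyl)carbamoyl)amino group on the amide-type nitrogen gives a 1.5-fold higher number from compound 2 to compound 3 (0.18 log units; within the scatter), so compound 2 and compound 3 cannot be told apart on this read-out even though the change is much larger than hydroxy for chloro. The comparison with the 3-chlorophenyl group gives a 3.3-fold higher number from compound 1 to compound 3 (0.52 log units; beyond the scatter), which is beyond the scatter and leaves compound 1 with the stronger inhibition of that pair. Within these three compounds, neither lengthening the group on this nitrogen nor the two-group exchange brings the number below that of compound 1, and no measurement on hand accounts for either step.

The compounds shown leave open how much of the step from compound 1 to compound 3 belongs to the added carbamoyl-amino link and how much to fluoro, as no pair here separates the two. Also open, as far as these compounds go, is whether an aminophenyl or carboxyphenyl group on the same amide-type nitrogen, or a longer chain linking this urea to the shared core, would move the number in this assay at all.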